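Removing the nitro group: what to expect for compound 4

The source may hold more compounds than are shown below. What is called first, only, known or untested is meant among the compounds shown, and "the series" means these compounds.

Three analogues on the shared core have been measured. Compound 1 `Cc1ccc(NC(=O)Nc2nc(-c3cc4cc(Br)ccc4o3)cs2)cc1` carries 4-methylphenyl; in a physicochemical assay, with a stated time of 6 min (on this read-out lower numbers stand for stronger inhibition and higher numbers for weaker inhibition), compound 1 returns only a limit, > 200000 nM. Compound 2 `O=C(Nc1cccc([N+](=O)[O-])c1)Nc1nc(-c2cc3cc(Br)ccc3o2)cs1` carries 3-nitrophenyl and gives 159000 nM in this assay; compound 3 `O=C(Nc1nc(-c2cc3cc(Br)ccc3o2)cs1)Nc1ccccc1[N+](=O)[O-]` carries 2-nitrophenyl and gives 166000 nM. Compound 3 thus holds the higher of the two numbers, with compound 2 as its nearest neighbour, a 1.0-fold higher number from compound 2 to compound 3 (0.02 log units; within the scatter). Against compound 1 the steps are an at least 1.2-fold lower number from compound 1 to compound 2 (0.09 log units; that floor lies within the scatter) and an at least 1.2-fold lower number from compound 1 to compound 3 (0.08 log units; that floor lies within the scatter).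

Compound 4 `O=C(Nc1ccccc1)Nc1nc(-c2cc3cc(Br)ccc3o2)cs1` is the next member: hydrogen in place of nitro on an aromatic carbon. Among the compounds with values here, the change undoes part of the one taken from compound 1 to compound 3, and every step so far, whether the substituent on the phenyl is moved or swapped, has stayed within the scatter. The one hint of direction is that the compound lacking a nitro group, compound 1, returned no number but a limit, (the limit of > 200000 nM in this assay, at which 1 of the 3 values shown sits). The expected step of a 1.2-fold higher number from compound 3 to compound 4 (0.08 log units; within the scatter) is therefore small, if anything toward higher numbers. Compound 4 is expected near 200000 nM, within 80000 nM to 500000 nM, with a real chance of another limit.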

Compound 4, half-maximal inhibitory concentration: > 200000 nM
Compound 4 was reported as a limit; the forecaster's own chance of this, stated with the estimate: 45%; the middle value sits exactly at the limit.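

Removing the nitro group takes the series from a number to a limit in this assay: compound 4 gives > 200000 nM, which is a limit and not a number. The readable steps are an at least 1.2-fold higher number from compound 3 to compound 4 (0.08 log units; that floor lies within the scatter) and an at least 1.2-fold higher number from compound 2 to compound 4 (0.09 log units; that floor lies within the scatter), so neither floor shows a change beyond the scatter, and the step between compound 1 and compound 4 cannot be read. Among these compounds, only the two nitrophenyl compounds return numbers, and none of the four goes against this: the limit of > 200000 nM in this assay, at which 2 of the 4 values shown sit.

Going by these compounds, the true size of the steps from the nitrophenyl compounds to compound 4 stays open. Also open, on these data alone, is whether an amine or a carboxylic acid in place of the nitro group would return a number.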